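Working notes: from compound 2 to compound 4

A few compounds are considered here, and "the series" means these few. Any claim that something is new, unique, unknown or untested is made for them only; others in the source may bear on it.

Measured in a functional assay on RPMI-8226 cells (Homo sapiens) for inhibition, read by sulforhodamine B assay, with a stated time of 48 h; a higher number here means a weaker inhibitor of growth, a lower number a stronger inhibitor of growth:
- compound 1 `O=C(Nc1cccc(-n2cc(-c3ccncc3)c(-c3ccc(Cl)c(O)c3)n2)c1)Nc1cccc(C(F)(F)F)c1`: > 32500 nM (a limit)
- compound 2 `COc1cc(-c2nn(-c3cccc(NC(=O)Nc4ccc(Cl)c(Cl)c4)c3)cc2-c2ccncc2)ccc1Cl`: 3260 nM
- compound 3 `O=C(Nc1cccc(-n2cc(-c3ccncc3)c(-c3ccc(Cl)c(O)c3)n2)c1)Nc1ccc(Cl)c(Cl)c1`: > 32500 nM (a limit)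

Among the compounds with values here, compound 2, at 3260 nM, holds the only actual number. The other two results are limits: the limit of > 32500 nM in this assay, at which 2 of the 3 values shown sit.

Compound 4 `COc1cc(-c2nn(-c3cccc(NC(=O)c4ccc(Cl)c(C(F)(F)F)c4)c3)cc2-c2ccncc2)ccc1Cl` carries 4-chloro-3-(trifluoromethyl)phenyl in place of (3,4-dichlorophenyl)amino on a carbonyl carbon.

Neither measured step gives a size for this change. The nearest is a step that the two limits leave unreadable from compound 1 to compound 3, for 3,4-dichlorophenyl in place of 3-(trifluoromethyl)phenyl on an amide-type nitrogen. The other, an at least 9.9-fold higher number from compound 2 to compound 3 (0.99 log units; beyond the scatter), concerns hydrogen in place of methyl on an oxygen on an aromatic ring, a different change.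

No step beyond the scatter is therefore expected in this assay, and the expected step is a 1.1-fold higher number from compound 2 to compound 4 (0.03 log units; within the scatter). The estimate for compound 4 is 3500 nM, with a range of 1200 nM to 15000 nM.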

Compound 4, concentration for total growth inhibition: > 32500 nM
Compound 4 ended at the assay's limit; the forecaster's own chance of this, stated with the estimate: 15%; middle value at least 9.2-fold (0.96 log units) from the limit.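

In this assay, within the data shown here, 4-chloro-3-(trifluoromethyl)phenyl in place of (3,4-dichlorophenyl)amino on the carbonyl carbon gives an at least 9.9-fold higher number from compound 2 to compound 4 (0.99 log units; beyond the scatter), the first readable step at this place. Keeping the methyl on the oxygen therefore does not by itself preserve a measurable value. Compound 4 stands at a limit of the assay, so the step gives only a minimum size: the limit of > 32500 nM in this assay, at which 3 of the 4 values shown sit.

Going by these compounds, whether the change comes from losing the amino nitrogen or from exchanging the ring's substituents stays open. (4-Chloro-3-(trifluoromethyl)phenyl)amino on the same carbonyl carbon would separate the two.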